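The source may hold more compounds than are shown below. What is called first, only, known or untested is meant among the compounds shown, and "the series" means these compounds.

Compound 1 `CN(C)[C@H]1C[C@H](c2c[nH]c3ccc(C(N)=O)cc32)C1` gives 44.7 nM in an assay on CHO-K1 cells for binding affinity to 5-hydroxytryptamine receptor 1B (Homo sapiens); a lower number here means a stronger inhibitor, a higher number a weaker inhibitor. Compound 2 `CN(C)[C@H]1C[C@H](c2c[nH]c3ccc(C(=O)NCc4ccccc4)cc32)C1` gives 316 nM in this assay. Compound 3 `Cc1noc(Cc2ccc3[nH]cc([C@H]4C[C@H](N(C)C)C4)c3c2)n1` gives 1510 nM in this assay.

Compound 3 has the highest number of the three, the weakest binding shown here, and the step of a 34-fold higher number from compound 1 to compound 3 (1.53 log units; beyond the scatter) sets it well apart from compound 1. Compound 4 `Cc1nc(Cc2ccc3[nH]cc([C@H]4C[C@H](N(C)C)C4)c3c2)n[nH]1` differs from compound 3 by 5-methyl-1H-1,2,4-triazol-3-yl in place of 3-methyl-1,2,4-oxadiazol-5-yl on a saturated chain carbon bound to an aromatic carbon. Neither measured step, a 7.1-fold higher number from compound 1 to compound 2 (0.85 log units; beyond the scatter) nor a 34-fold higher number from compound 1 to compound 3 (1.53 log units; beyond the scatter), swaps one five-membered ring for another, so there is no direct guide to the size or direction of this change. The expectation is therefore a step of a 1.3-fold lower number from compound 3 to compound 4 (0.10 log units; within the scatter) that stays within the scatter. Compound 4 is estimated at 1200 nM, with a range from 350 nM to 4000 nM.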

Compound 4, half-maximal inhibitory concentration: 3890 nM
For compound 4 the middle estimate is 3.2-fold (0.51 log units) below the measured one, within the range that was stated.
By their numbers in this assay, from the lowest: compound 1; then compound 2; then compound 3; then compound 4.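

In this assay, a swap of one five-membered aromatic ring for another with the same 6 heavy atoms still counts: 5-methyl-1H-1,2,4-triazol-3-yl in place of 3-methyl-1,2,4-oxadiazol-5-yl gives a 2.6-fold higher number from compound 3 to compound 4 (0.41 log units; beyond the scatter). Neither ring group matches the carbamoyl of compound 1, and the triazole group falls further behind, with an 87-fold higher number from compound 1 to compound 4 (1.94 log units; beyond the scatter). No evidence here explains this difference.

Still open, going by these compounds, is whether an amine or a carboxylic acid in place of either ring would bring the number back toward that of compound 1. On these data alone, whether a longer chain carrying the 5-methyl-1H-1,2,4-triazol-3-yl would do so is equally open.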